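A few compounds are considered here, and "the series" means these few. Any claim that something is new, unique, unknown or untested is made for them only; others in the source may bear on it.

Of the compounds shown here, two have so far been measured in an assay on CHO cells for binding affinity to prostaglandin E2 receptor EP4 subtype (Mus musculus); a higher number here means a weaker inhibitor, a lower number a stronger inhibitor. Compound 1 `COCc1cccc(C[C@H](O)/C=C/[C@H]2[C@H](O)CC(=O)[C@@H]2CCSCCCC(=O)O)c1` gives 0.7 nM. Compound 2 `CCCCC[C@H](O)/C=C/[C@H]1[C@H](O)CC(=O)[C@@H]1CSCCCCC(=O)O` gives 8.7 nM. Of these two numbers, compound 2 holds the higher one. The gap between the two lies well beyond the scatter, and compound 2 is the weaker binder of the pair.

Compound 3 `CCCCC[C@H](O)/C=C/[C@H]1[C@H](O)CC(=O)[C@@H]1CCSCCCC(=O)O` is built from the same atoms as compound 2, joined differently: ((3-carboxypropyl)sulfanyl)methyl in place of (4-carboxybutyl)sulfanyl on a saturated chain carbon bound to a saturated ring carbon. The acid-bearing chain thus keeps its overall length, with the sulfur shifted within it. Compound 1 carries the same arrangement of this chain and differs from compound 3 only in the other side chain.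

Within the data shown here, no measured pair shows this exact rearrangement, so its size can only be guessed. Still, the change is expected to lower the number, a 4.4-fold lower number from compound 2 to compound 3 (0.64 log units; beyond the scatter), since compound 1 with the same chain arrangement gives 0.7 nM. In this assay compound 3 is therefore estimated at 2 nM, with a plausible range from 0.5 nM to 8 nM.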

Compound 3, inhibition constant: 0.5 nM
Beside the measured number, compound 3's estimate is 4.0-fold (0.60 log units) above it, within the range that was stated.
By their numbers in this assay, from the lowest: compounds 3 and 1 (each within the scatter of the next); then compound 2.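

In this assay, swapping (4-carboxybutyl)sulfanyl for ((3-carboxypropyl)sulfanyl)methyl on a saturated chain carbon bound to a saturated ring carbon gives a 17-fold lower number from compound 2 to compound 3 (1.24 log units; beyond the scatter), so with no atom gained or lost, the way this acid-bearing chain is joined makes a large difference to the number. The other side chain behaves quite differently: butyl in place of 3-(methoxymethyl)phenyl gives a 1.4-fold lower number from compound 1 to compound 3 (0.15 log units; within the scatter), so among compounds carrying the ((3-carboxypropyl)sulfanyl)methyl chain, this much larger swap leaves the number within the scatter. Nothing available explains why the rearranged chain gives the lower number.

Still open, on these data alone, is how far the result depends on the sulfur itself, for instance whether an oxygen in its place, or a longer chain leading to the carboxylic acid, would keep the number this low. Also open, as far as these compounds go, is whether butyl and 3-(methoxymethyl)phenyl would stay this close on the (4-carboxybutyl)sulfanyl chain, since their comparison rests on a single pair.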